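From methylsulfonyl to (4-methylphenyl)sulfonyl in compound 4

This account rests on a few compounds, and the source may have more. Where it says the series, first, only, none or still open, it means among the compounds named here.

Values so far in an ADME assay on HEp-2 cells (Homo sapiens) for cytotoxicity, read by MTT assay, with a stated time of 60 h (a higher number here means that more compound is tolerated, a lower number that less compound is tolerated), are these
compound 1 `Cc1c(Br)cc2nc3n(c2c1Br)[C@H]1OC[C@@H](OS(C)(=O)=O)[C@H]1OC3` gives 23700 nM
compound 2 `CS(=O)(=O)O[C@@H]1CO[C@H]2[C@@H]1OCc1nc3cc(Br)c(Br)cc3n12` gives 99500 nM
compound 3 `Cc1c(Br)cc2c(nc3n2[C@H]2OC[C@@H](O)[C@H]2OC3)c1Br` gives 34300 nM

Compound 1 stands within the usual scatter of compound 3, while compound 2 gives a higher number, beyond that scatter. Compound 4 `Cc1ccc(S(=O)(=O)O[C@@H]2CO[C@H]3[C@@H]2OCc2nc4cc(Br)c(C)c(Br)c4n23)cc1` keeps the core of compound 1 and carries 4-methylphenyl in place of methyl on a sulfonyl sulfur. Going by the values given here, no measured pair shows this change, so the expectation is loose: in this assay no shift beyond the scatter is expected. The expected 1.2-fold lower number from compound 1 to compound 4 (0.07 log units; within the scatter) is small. For compound 4 the estimated value is 20000 nM and the expected range runs from 6000 nM to 70000 nM in this estimate.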

Compound 4, half-maximal cytotoxic concentration: 88600 nM
Compound 4: the middle estimate sits 4.4-fold (0.65 log units) below what was measured, and the stated range ends below it.
By their numbers in this assay, from the lowest: compounds 1 and 3 (each within the scatter of the next); then compounds 4 and 2 (each within the scatter of the next).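

In this assay, the sulfonyl sulfur proves not to be a silent place: 4-methylphenyl in place of methyl gives a 3.7-fold higher number from compound 1 to compound 4 (0.57 log units; beyond the scatter) and so a modest move towards more compound being tolerated. This is the only step shown between compounds that differ in one place. Nothing measured here explains the shift.
On these data alone, with a single pair, it remains open whether the ring or its methyl matters. As far as these compounds go, what ethyl or unsubstituted phenyl on the same sulfonyl sulfur would give also remains open.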